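Two Acetylated Lactones and the Free Diol to Come

The compounds below may be only part of what the source reports. "The series", "measured", "known", "first", "only" and "open" are said of these compounds alone.

Compound 1: `CCCC[C@H](O)/C=C\[C@@H]1OC(=O)C=C[C@@H]1OC(C)=O` — 5200 nM
Compound 2: `CCCC[C@@H](/C=C\[C@@H]1OC(=O)C=C[C@@H]1O)OC(C)=O` — 2300 nM

Both compounds were tested in a functional assay on HCT-15 cells (Homo sapiens) for cytotoxicity, read by sulforhodamine B assay, with a stated time of 48 h; a lower number here means a stronger inhibitor, a higher number a weaker inhibitor. Compound 1 gives 5200 nM. Among the compounds with values here, compound 2 gives 2300 nM, the lowest of the two numbers; its only neighbour is compound 1, whose number is higher by a margin beyond the usual scatter. Within the data shown here, the two compounds differ in more than one place, so no single step connects them, and the comparison says only that the pair sits apart.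

The next compound is compound 3 `CCCC[C@H](O)/C=C\[C@@H]1OC(=O)C=C[C@@H]1O`. Against compound 2 the change is hydrogen in place of acetyl on an oxygen on a saturated carbon. Among the measured compounds shown here, no measured step of this kind exists in the set, so the expectation rests on the two numbers alone, which show that the placement of the acetyl matters.

For the step from compound 2 to compound 3 a rise in the number is expected, a 1.7-fold higher number from compound 2 to compound 3 (0.24 log units; within the scatter), of a size that may or may not clear the scatter. Compound 3 is therefore estimated at 4000 nM, within a range from 1500 nM to 12000 nM.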

Compound 3, half-maximal inhibitory concentration: 7400 nM
Compound 3: middle estimate off by 1.9-fold (0.27 log units), on the low side, and the stated range covers the measured number.
By their numbers in this assay, from the lowest: compound 2; then compounds 1 and 3 (each within the scatter of the next).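

In this assay, exchanging acetyl for hydrogen on the chain oxygen, the one on a saturated carbon whose other neighbour is a saturated chain carbon, gives a 3.2-fold higher number from compound 2 to compound 3 (0.51 log units; beyond the scatter) and so clears the scatter. The same exchange on the other oxygen gives a 1.4-fold higher number from compound 1 to compound 3 (0.15 log units; within the scatter) and stays within the scatter. The change from acetoxy to hydroxy therefore has a readable effect at the chain oxygen and none that can be told apart from the scatter at the other, a contrast that the first two compounds, differing in more than one place, could not show. Nothing measured here explains why the two oxygens differ in this way.

The three compounds leave open whether acetyl on both oxygens at once would go further than the single acetyl on the chain oxygen, and whether the step depends on acetyl itself or would also appear with a longer acyl group such as butyryl or with a benzoyl group. They also leave open how a methyl ether or an amine at the chain position would compare with the hydroxy and acetoxy forms.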